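A few compounds are considered here, and "the series" means these few. Any claim that something is new, unique, unknown or untested is made for them only; others in the source may bear on it.

In an ADME assay on the whole organism with Oryza sativa as the target, tested at 1 uM (a higher number here means a weaker effect of the compound at the concentration tested, a lower number a stronger effect), the three measured compounds give these numbers:

compound 1 `CC(C)c1ccccc1NC(=O)N[C@H](C)c1ccccc1`: 101%
compound 2 `CC(C)c1ccccc1NC(=O)N[C@@H](C)c1ccccc1`: 96%
compound 3 `CCCCc1ccc(NC(=O)N[C@H](C)c2ccccc2)cc1`: 32%

Compound 2 stands second highest of the three; compound 1 lies close to it, and compound 3 lies far lower. For the measured compounds named here, the only step between measured compounds that differ in one place is a number 5 percentage points lower from compound 1 to compound 2 (within the scatter), and it rests on (the fact that compounds 1 and 2 differ only in the configuration as drawn), so it says nothing about exchanging a group on the ring. Compound 4 `C[C@H](NC(=O)Nc1ccccc1F)c1ccccc1` is compound 2 with fluoro in place of isopropyl on an aromatic carbon. Going by the values given here, no measured step swaps one ring substituent for another, so none bears directly on this change; compound 3 carries a different chain at a different place and also differs in configuration as drawn, so its lower number cannot be tied to a single change. The number of compound 2 leaves little room upward. The expectation is therefore a modest, uncertain drop, with a step of a number 11 percentage points lower from compound 2 to compound 4 (beyond the scatter). The estimated value for compound 4 is 85%, between 50% and 105%.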

Compound 4, a percentage reported as activity, at one concentration (the size of the read-out at that concentration, not a potency): 92%
Beside the measured number, compound 4's estimate is 7 percentage points below it; measured number inside the range.
By their numbers in this assay, from the lowest: compound 3; then compounds 4, 2 and 1 (each within the scatter of the next).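

In this assay, exchanging isopropyl for fluoro, ortho to a large group, gives a number 4 percentage points lower from compound 2 to compound 4 (within the scatter). For the compounds shown here, this is the first measured exchange of one group for another at this place, and it shows that going from a branched group of three heavy atoms to a single fluorine atom leaves no difference that can be told from the scatter. Nothing at hand gives a cause for this result, and the only available fact concerns a different kind of change.

Going by these compounds, it remains open whether any group at this place can move the number, for instance an amine or a carboxylic acid. What lies behind the far lower number of compound 3 also stays open, as it differs from compound 2 in more than one place.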